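This account rests on a few compounds, and the source may have more. Where it says the series, first, only, none or still open, it means among the compounds named here.

Compound 1 `C/C(=N\NC(=O)c1cccc(S(=O)(=O)N2CCOCC2)c1)c1ccccc1O` gives 5400 nM in a functional assay on MCF7 cells (Homo sapiens) for antiproliferative activity, read by MTT assay, with a stated time of 72 h; on this read-out lower numbers stand for stronger inhibition and higher numbers for weaker inhibition.
Compound 2 `C/C(=N\NC(=O)c1cccc(S(=O)(=O)N2CCOCC2)c1)c1cc(O)ccc1O` reaches only the limit > 100000 nM in this assay, a limit and not a number.
Compound 3 `C/C(=N\NC(=O)c1cccc(S(=O)(=O)N2CCOCC2)c1)c1cc(Br)ccc1O` gives 7830 nM in this assay.

Among the two numbers shown, compound 1 stands lowest, with compound 3 nearest, the step of a 1.5-fold higher number from compound 1 to compound 3 (0.16 log units; within the scatter) lying within the scatter. Compound 4 `C/C(=N\NC(=O)c1cccc(S(=O)(=O)N2CCOCC2)c1)c1cccc(N)c1O` differs from compound 1 by amino in place of hydrogen on an aromatic carbon. Among the measured compounds shown here, two measured steps bear on this change. Adding a hydroxy group to the same ring gives an at least 18-fold higher number from compound 1 to compound 2 (1.26 log units; beyond the scatter), a large loss, though compound 2 gives only a limit so the full size of that loss is unknown. Adding a bromo group to the same ring gives a 1.5-fold higher number from compound 1 to compound 3 (0.16 log units; within the scatter), nothing beyond the scatter. The amino group entering in compound 4 brings a hydrogen-bond donor and acceptor, as the hydroxy of compound 2 does, rather than the halogen of compound 3, so a higher number in this assay is expected for compound 4, of a size between those two outcomes. The estimated step from compound 1 is a 2.8-fold higher number from compound 1 to compound 4 (0.44 log units; beyond the scatter), expected beyond the scatter. Compound 4 is therefore estimated at 15000 nM, expected within 5000 nM to 60000 nM.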

Compound 4, half-maximal inhibitory concentration: 1010 nM
Estimate against measurement, compound 4: 15-fold (1.17 log units) above; measured number below the stated range.
By their numbers in this assay, from the lowest: compound 4; then compounds 1 and 3 (each within the scatter of the next). At a limit, above all of these: compound 2.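

In this assay the ring of compound 1 turns out to accept a new group with a gain: amino placed ortho to the hydroxy group gives a 5.3-fold lower number from compound 1 to compound 4 (0.73 log units; beyond the scatter), the only step among these compounds that runs downward from compound 1 beyond the scatter. The new compound also stands apart from the bromo compound, with a 7.8-fold lower number from compound 3 to compound 4 (0.89 log units; beyond the scatter), although 3-amino-2-hydroxyphenyl and 5-bromo-2-hydroxyphenyl differ both in the group and in its place, so this step cannot separate those two changes. Against 2,5-dihydroxyphenyl the step is an at least 99-fold lower number from compound 2 to compound 4 (1.99 log units; beyond the scatter), and it is only a bound, compound 2 giving a limit and not a number: the limit of > 100000 nM in this assay, at which 1 of the 4 values shown sits.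

The compounds shown leave open whether the gain belongs to the amino group itself or to its place ortho to the hydroxy group, as amino appears at no other place on the ring and no other group appears at this one. As far as these compounds go, whether a methoxy group or a dimethylamino group at this place would give a similar number, or whether an acetylated amine would keep the gain, also remains open.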